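A Pyridine Ring Replaces Trifluoromethylphenyl on a Shared Core

The compounds below may be only part of what the source reports. "The series", "measured", "known", "first", "only" and "open" are said of these compounds alone.

Three compounds share one core and differ only in the substituent on the aromatic group attached to the five-membered aromatic ring with 3 nitrogen. Compound 1 `C=C1C[C@]23C[C@@]1(O)CC[C@H]2c1ccc(OS(=O)(=O)c2ccc(C)cc2)c(C)c1[C@@H]3Cn1cc(-c2ccc(Br)cc2)nn1` carries a bromo there, compound 2 `C=C1C[C@]23C[C@@]1(O)CC[C@H]2c1ccc(OS(=O)(=O)c2ccc(C)cc2)c(C)c1[C@@H]3Cn1cc(-c2ccccc2)nn1` a hydrogen in its place, and compound 3 `C=C1C[C@]23C[C@@]1(O)CC[C@H]2c1ccc(OS(=O)(=O)c2ccc(C)cc2)c(C)c1[C@@H]3Cn1cc(-c2ccc(C(F)(F)F)cc2)nn1` a trifluoromethyl. In a functional assay on HL-60 cells (Homo sapiens) for cytotoxicity, read by MTT assay, with a stated time of 4 days (on this read-out higher numbers stand for weaker inhibition and lower numbers for stronger inhibition), compound 1 gives no number, only a limit of > 20000 nM. In this assay compound 2 likewise gives only a limit of > 20000 nM. In this assay compound 3 again gives only a limit of > 20000 nM. Compound 3 thus stands where every measured value stands, at the limit of > 20000 nM in this assay, at which 3 of the 3 values shown sit. The three steps among these compounds, a step that the two limits leave unreadable from compound 1 to compound 2, a step that the two limits leave unreadable from compound 1 to compound 3 and a step that the two limits leave unreadable from compound 2 to compound 3, cannot be sized; a limit gives no number to compare.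

Compound 4 `C=C1C[C@]23C[C@@]1(O)CC[C@H]2c1ccc(OS(=O)(=O)c2ccc(C)cc2)c(C)c1[C@@H]3Cn1cc(-c2ccccn2)nn1` differs from compound 3 in one place: pyridin-2-yl in place of 4-(trifluoromethyl)phenyl on an aromatic carbon. The measured steps bear on it only in that none of the three groups tried brought a value under the limit. Compound 4 is therefore expected to stay at or near the limit too, with an estimated value of 20000 nM and a range from 5000 nM to 60000 nM. For compound 4 this means an expected step of a number no higher from compound 3 to compound 4 (the limit leaves the size open), none beyond the scatter.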

Compound 4, half-maximal inhibitory concentration: > 20000 nM
Compound 4: only a limit was reported; the forecaster's own chance of this, stated with the estimate: 80%; the middle value lies on the limit itself.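

Going by these compounds alone, compound 4, like compound 1, compound 2 and compound 3, gives only a limit and no number, so no step among the four can be read in this assay: the limit of > 20000 nM in this assay, at which 4 of the 4 values shown sit. The compounds shown leave open how far apart these four truly lie, and whether any other group there would bring a value under the limit.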